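Amino in Place of Fluoro, Tried on a Second Core

The source may report more compounds than this note shows. Statements on the series, on what has been measured and on what is new or still open speak of the compounds shown alone.

This account concerns four compounds that share a trimethoxybenzoyl-bearing pyrrole carrying two aryl rings, measured in a functional assay on MCF7 cells (Homo sapiens) for inhibition, read by trypan blue exclusion, with a stated time of 3 days; a higher number here means a weaker inhibitor, a lower number a stronger inhibitor. Compound 1, `COc1cc(C(=O)c2cn(-c3ccccc3)cc2-c2cccc(F)c2)cc(OC)c1OC`, gives 57 nM in this assay. Compound 2, `COc1cc(C(=O)c2cn(-c3ccccc3)cc2-c2cccc(N)c2)cc(OC)c1OC`, carries an amino where compound 1 carries a fluoro: amino in place of fluoro on an aromatic carbon. In this assay compound 2 gives 28 nM. The step is a 2.0-fold lower number from compound 1 to compound 2 (0.31 log units; beyond the scatter). Compound 3, `COc1cc(C(=O)c2cn(-c3cccc(F)c3)cc2-c2ccccc2)cc(OC)c1OC`, has the same atoms as compound 1 joined differently; the difference between the two cores is not broken down here. In this assay compound 3 gives 350 nM, the highest number of the three measured, well beyond the scatter from both compound 1 and compound 2.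

Compound 4, `COc1cc(C(=O)c2cn(-c3cccc(N)c3)cc2-c2ccccc2)cc(OC)c1OC`, is not yet measured. It differs from compound 3 by the same change that separates compound 1 from compound 2: amino in place of fluoro on an aromatic carbon. The place is described in the same words for both pairs, so the change is counted as the same one, applied on the core of compound 3 rather than that of compound 1. Going by the values given here, the only guide to its size is the single earlier instance; with one example there is no way to tell whether it carries over across cores. The step from compound 3 to compound 4 is therefore expected to be a 2.0-fold lower number from compound 3 to compound 4 (0.30 log units; within the scatter), resting on compound 1 to compound 2 having given a 2.0-fold lower number from compound 1 to compound 2 (0.31 log units; beyond the scatter). Compound 4 is thus estimated at 175 nM in this assay, with a range from 70 nM to 500 nM.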

Compound 4, half-maximal inhibitory concentration: 74 nM
For compound 4 the middle estimate is 2.4-fold (0.37 log units) above the measured one; the measured number falls inside the stated range.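

On the core of compound 3, amino in place of fluoro again gives a lower number in this assay, with a 4.7-fold lower number from compound 3 to compound 4 (0.67 log units; beyond the scatter), so the change runs in the same direction on both cores shown and each step lies beyond the scatter. This shows that the direction carried over from one core to the other in these two pairs, but two pairs do not make a rule for the series, and the data say nothing about why the number falls or whether a further core would behave alike. The two steps cannot be told apart in size, so a real dependence on the core is neither shown nor excluded, and the larger step on the core of compound 3 should not be read as a stronger effect there: the same change on two cores in this assay, a 2.0-fold lower number (0.31 log units; beyond the scatter) from compound 1 to compound 2 and a 4.7-fold lower number (0.67 log units; beyond the scatter) from compound 3 to compound 4, 2.3-fold (0.37 log units) apart, within the scatter of two such steps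

The compounds shown compare only fluoro with amino, so it remains open whether a hydroxyl, a methoxy or an acetamide in the same place would follow the amino or the fluoro. On these data alone, it also remains open whether plain hydrogen there would give a number closer to the fluoro compounds or to the amino compounds on either core, and whether the same step would appear on other cell lines.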